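Series notes: 2-carboxyethenyl in place of acetamidomethyl

The source may hold more compounds than are shown below. What is called first, only, known or untested is meant among the compounds shown, and "the series" means these compounds.

Measured:
compound 1 `COc1ccc(-c2nc(CNC(C)=O)sc2-c2ccc(OC)cc2)cc1` — 15 nM
compound 2 `CCOC(=O)C1=C(C)N=C(C)/C(=C(/O)OCC)C1c1nc(-c2ccc(OC)cc2)c(-c2ccc(OC)cc2)s1` — < 100 nM

Within the data shown here, in a functional assay with Oryctolagus cuniculus as the target (on this read-out higher numbers stand for weaker inhibition and lower numbers for stronger inhibition), compound 1 gives 15 nM, the only plain number among the two results. For compound 2 the result in this assay is a limit of the assay, < 100 nM, not a number. Compound 3 `COc1ccc(-c2nc(/C=C/C(=O)O)sc2-c2ccc(OC)cc2)cc1` differs from compound 1 by 2-carboxyethenyl in place of acetamidomethyl on an aromatic carbon. Among the measured compounds shown here, no step between measured compounds covers this change, and 2-carboxyethenyl occurs in no measured compound. The step from compound 1 to compound 3 in this assay is expected to be small, toward weaker inhibition, near the edge of the scatter: a 2.7-fold higher number from compound 1 to compound 3 (0.43 log units; beyond the scatter). Compound 3 is estimated at 40 nM, within 8 nM to 200 nM.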

Compound 3, half-maximal inhibitory concentration: > 100 nM
Compound 3 ended at the assay's limit (the forecaster's own chance of this, stated with the estimate: 10%); middle value at least 2.5-fold (0.39 log units) away from the limit.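

In this assay, 2-carboxyethenyl in place of acetamidomethyl on this aromatic carbon gives an at least 6.6-fold higher number from compound 1 to compound 3 (0.82 log units; beyond the scatter). Among these compounds, this is the first direct reading of this position, and it shows that inhibition here changes with the group carried, toward weaker inhibition for this change. The result for compound 3 is a limit of the assay, so the step has no upper end: the limit of > 100 nM in this assay, at which 1 of the 3 values shown sits.

As far as these compounds go, whether the shift follows the free acid or the ethenyl link stays open. An ethyl ester of the same chain, a saturated propanoic acid chain or a simple aminomethyl group at this position would separate these.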